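The source may report more compounds than this note shows. Statements on the series, on what has been measured and on what is new or still open speak of the compounds shown alone.

Compound 3 `CCN(CC)CCNC(=O)c1ccc(C(CC)(CC)c2ccc(OCC(O)C(C)(C)C)c(C)c2)n1CC` gives 110 nM in an assay on HL-60 cells for agonist activity at vitamin D3 receptor (Homo sapiens), read by microscopy, with a stated time of 96 h (a lower number here means that less compound is needed, a higher number that more compound is needed for the effect), standing second highest among the three measured compounds; compound 1 `CCN(CC)CCNC(=O)c1ccc(C(CC)(CC)c2ccc(OCC(=O)C(C)(C)C)c(C)c2)n1CC` gives 91 nM, separated from it only by a 1.2-fold higher number from compound 1 to compound 3 (0.08 log units; within the scatter), while compound 2 `C#CCCOC(=O)c1ccc(C(CC)(CC)c2ccc(OCC(=O)C(C)(C)C)c(C)c2)n1CC` gives 28800 nM. Compound 4 `CCOc1ccc(NC(=O)c2ccc(C(CC)(CC)c3ccc(OCC(O)C(C)(C)C)c(C)c3)n2CC)cc1` differs from compound 3 at one place: 4-ethoxyphenyl in place of 2-(diethylamino)ethyl on an amide-type nitrogen. The measured step that bears on this is a 320-fold higher number from compound 1 to compound 2 (2.50 log units; beyond the scatter), where the group on the carbonyl carbon was exchanged; the step of a 1.2-fold higher number from compound 1 to compound 3 (0.08 log units; within the scatter) concerns a change elsewhere in the molecule. Compound 4 likewise loses the 2-(diethylamino)ethyl group, so the expected step in this assay is a 9.1-fold higher number from compound 3 to compound 4 (0.96 log units; beyond the scatter), a rise, though one kept short of the step to compound 2 with the amide retained. Compound 4 is therefore estimated at 1000 nM, between 200 nM and 6000 nM.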

Compound 4, half-maximal effective concentration: 630 nM
Estimate against measurement, compound 4: 1.6-fold (0.20 log units) above; low and high end bracket the measured number.
By their numbers in this assay, from the lowest: compounds 1 and 3 (each within the scatter of the next); then compound 4; then compound 2.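

Taking 2-(diethylamino)ethyl off the amide-type nitrogen raises the number even with the amide kept, and the measured step is a 5.7-fold higher number from compound 3 to compound 4 (0.76 log units; beyond the scatter) in this assay. That rise is much smaller than a 320-fold higher number from compound 1 to compound 2 (2.50 log units; beyond the scatter) where the amide gave way to an ester, although that step was read on compounds with the carbonyl and this one on compounds with the hydroxyl. Nothing measured here explains the rise. Going by these compounds, whether it follows the lost diethylamino group or the entering aromatic ring stays open. A plain butyl chain or a 2-(dimethylamino)ethyl group on that nitrogen would help separate the two.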